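The compounds below may be only part of what the source reports. "The series", "measured", "known", "first", "only" and "open" are said of these compounds alone.

Compound 1 `Cc1c(Nc2nc(N)c3c(C#N)c(N4CCC[C@H]4C)n(C)c3n2)cnn1C`: 2 nM
Compound 2 `C[C@@H]1CCCN1c1c(C#N)c2c(N)ncnc2n1C`: 0.4 nM
Compound 3 `Cn1c(-c2ccccc2)c(C#N)c2c(N)ncnc21`: 30 nM

All three were measured in an assay on isolated protein for binding affinity to Leucine-rich repeat serine/threonine-protein kinase 2 (Homo sapiens), read by TR-FRET and LanthaScreen, with a stated time of 2 h; on this read-out lower numbers stand for stronger inhibition and higher numbers for weaker inhibition. Compound 2 gives the lowest number of the three. Its nearest neighbour is compound 1, separated by the step of a 5.0-fold lower number from compound 1 to compound 2 (0.70 log units; beyond the scatter); the furthest is compound 3, separated by the step of a 75-fold higher number from compound 2 to compound 3 (1.88 log units; beyond the scatter).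

Compound 4 `C[C@@H]1CCCN1c1c(C(N)=O)c2c(N)ncnc2n1C` differs from compound 2 by carbamoyl in place of cyano on an aromatic carbon. Neither measured step touches this place: the step of a 5.0-fold lower number from compound 1 to compound 2 (0.70 log units; beyond the scatter) removes a group on a different ring, and the step of a 75-fold higher number from compound 2 to compound 3 (1.88 log units; beyond the scatter) replaces the 2-methylpyrrolidin-1-yl group, while the cyano group is kept in compounds 1, 2 and 3. There is therefore no measured guide to this exchange. Since the rest of compound 2 is unchanged, only a small step is expected, with a slightly higher number the more likely direction. The step this implies, expected rather than measured, is a 2.5-fold higher number from compound 2 to compound 4 (0.40 log units; beyond the scatter). Compound 4 is estimated at 1 nM, expected to fall between 0.3 nM and 4 nM.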

Compound 4, inhibition constant: 77 nM
Estimate against measurement, compound 4: 77-fold (1.89 log units) below; the measured number lies above the stated range.
By their numbers in this assay, from the lowest: compound 2; then compound 1; then compound 3; then compound 4.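

Compounds 1, 2 and 3 all keep the cyano group, so they say nothing about this aromatic carbon on the five-membered ring. In this assay, among these compounds, putting carbamoyl in place of cyano gives a 190-fold higher number from compound 2 to compound 4 (2.28 log units; beyond the scatter), so a change of only one small group at this position can cost a great deal of binding, and this step is large, as is a 75-fold higher number from compound 2 to compound 3 (1.88 log units; beyond the scatter) at the place of the 2-methylpyrrolidin-1-yl group. No measurement at hand accounts for why carbamoyl does so much worse than cyano.

These compounds cannot show whether the loss is particular to carbamoyl or follows any departure from cyano, such as a methyl group, a chlorine atom or a carboxylic acid. From the compounds shown here alone, it also remains open whether the same exchange would cost as much with the (1,5-dimethyl-1H-pyrazol-4-yl)amino group of compound 1 in place.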